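This account rests on a few compounds, and the source may have more. Where it says the series, first, only, none or still open, it means among the compounds named here.

Working notes on the series in a functional assay on HepG2 cells (Homo sapiens) for antiproliferative activity, read by MTT assay, with a stated time of 48 h; a lower number here means a stronger inhibitor, a higher number a weaker inhibitor. Compound 1 `O=c1cc(-c2ccccc2)oc2cc(OCc3ccccc3)c(OCCCCN3CCCCC3)c(O)c12` gives 2400 nM, compound 2 `CN1CCN(CCCCOc2c(OCc3ccccc3)cc3oc(-c4ccccc4)cc(=O)c3c2O)CC1` gives 2500 nM and compound 3 `CN(C)CCCOc1c(OCc2ccccc2)cc2oc(-c3ccccc3)cc(=O)c2c1O` gives 2200 nM. These three values lie within the scatter of one another, so compound 3 is not separated from either neighbour.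

Compound 4 `O=c1cc(-c2ccccc2)oc2cc(OCc3ccccc3)c(OCCCCN3CCCC3)c(O)c12` is the next to be read against compound 3. The difference is (pyrrolidin-1-yl)methyl in place of dimethylamino on a saturated chain carbon, three bonds along the chain from an oxygen on an aromatic ring. In words, (pyrrolidin-1-yl)methyl stands in place of dimethylamino on a saturated chain carbon, three bonds along the chain from an oxygen on an aromatic ring. Cut one bond further out, this reads 3-(dimethylamino)propyl to 4-(pyrrolidin-1-yl)butyl.

Two measured exchanges at the same place bear most directly on this change: a 1.1-fold lower number from compound 1 to compound 3 (0.04 log units; within the scatter) and a 1.1-fold lower number from compound 2 to compound 3 (0.06 log units; within the scatter). The swap of the ring group on the butyl chain adds a 1.0-fold higher number from compound 1 to compound 2 (0.02 log units; within the scatter). All three steps stay within the scatter, and none of the three compounds goes against this flat picture. No five-membered ring has been measured in this series yet, so the reading is an extrapolation. No step beyond the scatter is expected in this assay, and no direction is favoured. The estimated step is a 1.1-fold higher number from compound 3 to compound 4 (0.04 log units; within the scatter). For compound 4 the expected value is 2400 nM, with an estimated range of 1200 nM to 4500 nM.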

Compound 4, half-maximal inhibitory concentration: 2000 nM
For compound 4 the middle estimate is 1.2-fold (0.08 log units) above the measured one, and the stated range covers the measured number.
By their numbers in this assay, from the lowest: compounds 4, 3, 1 and 2 (each within the scatter of the next).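

In this assay, a five-membered ring on the chain, as 4-(pyrrolidin-1-yl)butyl, does not separate from any of the earlier amines: the steps (a 1.1-fold lower number from compound 3 to compound 4 (0.04 log units; within the scatter)), (a 1.3-fold lower number from compound 2 to compound 4 (0.10 log units; within the scatter)) and (a 1.2-fold lower number from compound 1 to compound 4 (0.08 log units; within the scatter)) all stay within the scatter. The flat picture now covers pyrrolidin-1-yl, piperidin-1-yl and 4-methylpiperazin-1-yl on the butyl chain as well as 3-(dimethylamino)propyl, and none of the four compounds goes against it. No supporting evidence bears on this result, so the flatness stands as an observation without an explanation.

The exchange between 3-(dimethylamino)propyl and 4-(pyrrolidin-1-yl)butyl alters the chain and the amine together, so the compounds shown do not give the contribution of either alone, for instance through 4-(dimethylamino)butyl or 3-(pyrrolidin-1-yl)propyl. From the compounds shown here alone, it also remains open whether the flat picture would hold for a morpholin-4-yl group, a carboxylic acid in place of the amine, or a hexyl chain carrying the same rings.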